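Estimating a Methyl Addition in a Histamine Receptor Series

The compounds below may be only part of what the source reports. "The series", "measured", "known", "first", "only" and "open" are said of these compounds alone.

Measured compounds:
Compound 1 `CC1CCCN1C1CCN(c2ccc(NC(=O)NC3CCCCC3)cc2)C1` gives 4.1 nM in an assay on CHO cells for displacement of a labelled ligand from histamine receptor H3 (Macaca mulatta), read by scintillation counting, with a stated time of 1 h; on this read-out lower numbers stand for stronger inhibition and higher numbers for weaker inhibition.
Compound 2 `Cc1cc(N2CCC(N3CCCC3C)C2)ccc1NC(=O)NC1CCCCC1` gives 4.6 nM.
Compound 3 `CC1CCCN1C1CCN(c2ccc(NC(=O)NCc3cccs3)cc2)C1` gives 1.9 nM.

Compound 2 differs from compound 1 by methyl in place of hydrogen on an aromatic carbon, and this gave a 1.1-fold higher number from compound 1 to compound 2 (0.05 log units; within the scatter). Compound 3 differs from compound 1 by (thiophen-2-yl)methyl in place of cyclohexyl on an amide-type nitrogen, and this gave a 2.2-fold lower number from compound 1 to compound 3 (0.33 log units; beyond the scatter). Compound 3 therefore stands with the lowest number of the three, with both compound 1 and compound 2 beyond the scatter from it.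

Compound 4 `Cc1cc(NC(=O)NCc2cccs2)ccc1N1CCC(N2CCCC2C)C1` has not yet been measured in this assay. It differs from compound 3 by methyl in place of hydrogen on an aromatic carbon. This is the same change already made from compound 1 to compound 2, occurring twice among the compounds shown, and its surroundings are described in the same words in both cases; the two cores themselves differ as described for compound 1 and compound 3. Since the earlier step was a 1.1-fold higher number from compound 1 to compound 2 (0.05 log units; within the scatter), compound 4 is expected to give a step of a 1.1-fold higher number from compound 3 to compound 4 (0.04 log units; within the scatter), lying within the scatter. Compound 4 is thus estimated at 2.1 nM, between 1 nM and 4.5 nM.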

Compound 4, inhibition constant: 8.4 nM
The estimate for compound 4 lay 4.0-fold (0.60 log units) below the measured number; the measured number lies above the stated range.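

In this assay, methyl in place of hydrogen on an aromatic carbon gave a 4.4-fold higher number from compound 3 to compound 4 (0.65 log units; beyond the scatter), so a step read on one core could not be carried to the other as it stood. These two cases do not show what separates them: the cores differ by (thiophen-2-yl)methyl in place of cyclohexyl, and although the methyl stands ortho to a large group in both compound 2 and compound 4, that large group is not the same one, so core and placement cannot be told apart here. What can be said is limited to a single pair of steps, which disagree in size: the same change on two cores in this assay, a 1.1-fold higher number (0.05 log units; within the scatter) from compound 1 to compound 2 and a 4.4-fold higher number (0.65 log units; beyond the scatter) from compound 3 to compound 4, 3.9-fold (0.60 log units) apart, beyond the scatter of two such steps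

The compounds shown leave open how a fluorine atom or a methoxy group on the same aromatic carbon would read in this assay. They also leave open whether a benzyl group in place of (thiophen-2-yl)methyl would give a methyl step closer to the one on the core of compound 1 or to the one on the core of compound 3.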